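The source may hold more compounds than are shown below. What is called first, only, known or untested is meant among the compounds shown, and "the series" means these compounds.

Of the compounds shown here, three that share one core have been measured in a functional assay on A549 cells (Homo sapiens) for antiproliferative activity, read by MTT assay; on this read-out lower numbers stand for stronger inhibition and higher numbers for weaker inhibition. In this assay compound 1 `COc1cc2c(Oc3ccc(NC(=O)Nc4ccccc4F)cc3)ccnc2cc1OCCCCCCC(=O)NO` gives 870 nM, compound 2 `COc1ccccc1NC(=O)Nc1ccc(Oc2ccnc3cc(OCCCCCCC(=O)NO)c(OC)cc23)cc1` gives 16200 nM, and compound 3 `COc1cc2c(Oc3ccc(NC(=O)N/N=C/c4ccccc4F)cc3)ccnc2cc1OCCCCCCC(=O)NO` gives 7780 nM. Compound 3 therefore holds the middle place, with a number somewhat lower than that of compound 2 and clearly higher than that of compound 1.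

Compound 4 `COc1cc2c(Oc3ccc(NC(=O)NNC(=O)c4ccccc4F)cc3)ccnc2cc1OCCCCCCC(=O)NO` has not yet been measured. It differs from compound 3 at one place, where ((2-fluorophenyl)carbonyl)amino enters: a group of 10 heavy atoms (7 carbon, 1 nitrogen, 1 oxygen, 1 fluorine; one six-membered aromatic ring of carbon only) in place of a group of 9 heavy atoms (7 carbon, 1 nitrogen, 1 fluorine; one six-membered aromatic ring of carbon only), on an amide-type nitrogen.

Two measured steps involve this same nitrogen. One is modest, an 8.9-fold higher number from compound 1 to compound 3 (0.95 log units; beyond the scatter), and the other is also modest but runs the opposite way, a 2.1-fold lower number from compound 2 to compound 3 (0.32 log units; beyond the scatter). So changes at this place have moved the number in both directions, but neither step is the swap made here, and no measured compound carries the entering group. The large step of a 19-fold higher number from compound 1 to compound 2 (1.27 log units; beyond the scatter) comes from methoxy in place of fluoro on an aromatic carbon, a different change, so it offers little guidance.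

With no firm direction to follow, the expected outcome is a 1.2-fold higher number from compound 3 to compound 4 (0.06 log units; within the scatter), which is no clear change beyond the scatter. For compound 4 the estimated value is 9000 nM, with a likely range from 2500 nM to 30000 nM.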

Compound 4, half-maximal inhibitory concentration: 2420 nM
For compound 4 the middle estimate is 3.7-fold (0.57 log units) above the measured one; measured number below the stated range.
By their numbers in this assay, from the lowest: compound 1; then compound 4; then compound 3; then compound 2.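

In this assay, the group entering on this amide-type nitrogen brings a carbonyl and a hydrogen-bond donor, which the group it replaces lacks, and the result is a 3.2-fold lower number from compound 3 to compound 4 (0.51 log units; beyond the scatter). Group size alone does not order these compounds: ((2-fluorophenyl)carbonyl)amino is the largest group shown at this place, yet the change gives a 6.7-fold lower number from compound 2 to compound 4 (0.83 log units; beyond the scatter), and compound 2 and compound 3 show that a smaller group can give a higher number. The extended group still does not match the directly attached 2-fluorophenyl, with a 2.8-fold higher number from compound 1 to compound 4 (0.44 log units; beyond the scatter), so this is a partial recovery rather than a gain over the best compound shown.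

No measurement shown explains why the entering group gives a lower number than the group it replaces. As far as these compounds go, the carbonyl, the hydrogen-bond donor and the ring are also changed together here, so it remains open which of them matters, and whether a group such as acetylamino, with no aromatic ring, or a longer chain carrying a carboxylic acid would be tolerated on this nitrogen.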